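A few compounds are considered here, and "the series" means these few. Any claim that something is new, unique, unknown or untested is made for them only; others in the source may bear on it.

Measured compounds in a functional assay on A549 cells (Homo sapiens) for antiproliferative activity, read by MTT assay, with a stated time of 48 h; on this read-out higher numbers stand for weaker inhibition and lower numbers for stronger inhibition:
- compound 1 `N#CC1=C(N)Oc2c(c3nc4ccccc4nc3c3ccccc23)C12C(=O)N(Cc1cnnn1-c1ccc(Cl)cc1)c1ccccc12`: > 50000 nM, a limit of the assay, not a number
- compound 2 `CCOc1ccccc1-n1nncc1CN1C(=O)C2(C(C#N)=C(N)Oc3c2c2nc4ccccc4nc2c2ccccc32)c2ccccc21`: > 50000 nM, likewise a limit
- compound 3 `N#CC1=C(N)Oc2c(c3nc4ccccc4nc3c3ccccc23)C12C(=O)N(Cc1cnnn1-c1ccc(N)cc1)c1ccccc12`: > 50000 nM, likewise a limit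

Compound 1 thus stands only at a limit in this assay, and the same holds for the two other measured members of the series; the three values sit together at the limit of > 50000 nM in this assay, at which 3 of the 3 values shown sit. The measured steps give no readable size: a step that the two limits leave unreadable from compound 1 to compound 2, a step that the two limits leave unreadable from compound 1 to compound 3 and a step that the two limits leave unreadable from compound 2 to compound 3 all run between limits, so none of them shows whether a change on the aromatic nitrogen of the five-membered ring moves the read-out at all.

Compound 4 `Cc1ccc(Cl)cc1-n1nncc1CN1C(=O)C2(C(C#N)=C(N)Oc3c2c2nc4ccccc4nc2c2ccccc32)c2ccccc21` differs from compound 1 in one place: 5-chloro-2-methylphenyl in place of 4-chlorophenyl on an aromatic nitrogen. Going by the values given here, the steps that bear on this change are the three above, and each is unreadable; no measured step points in either direction. Since every change so far at this position has left the compound at the limit, compound 4 is expected to stay there too, and the step that the limit leaves unreadable from compound 1 to compound 4 is estimated to be nothing beyond the scatter. For compound 4 the estimate in this assay is 100000 nM, within 40000 nM to 300000 nM, most likely reported again as a limit.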

Compound 4, half-maximal inhibitory concentration: > 50000 nM
Compound 4: only a limit was reported; the forecaster's own chance of this, stated with the estimate: 85%; the middle value does not contradict the limit.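

No new step can be read: the steps joining compound 4 to compound 1, compound 2 and compound 3 all run between limits of the assay. The compounds shown leave open whether any group on the aromatic nitrogen moves the read-out at all, as all of them sit together: the limit of > 50000 nM in this assay, at which 4 of the 4 values shown sit.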